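The compounds below may be only part of what the source reports. "The series", "measured", "known", "first", "only" and "open" are said of these compounds alone.

Measured so far in a physicochemical assay for solubility; on this read-out lower numbers stand for lower solubility and higher numbers for higher solubility:
compound 1 `O=S(=O)(Nc1ccncn1)c1ccc2c(c1)OCC[C@@H]2c1ccc(C(F)(F)F)cc1-c1ccc(F)cn1` gives 181000 nM
compound 2 `O=C1OCCN1c1cc(C(F)(F)F)ccc1[C@H]1CCOc2cc(S(=O)(=O)Nc3nccs3)ccc21` gives 295000 nM
compound 3 `Cc1ccc(-c2cc(C(F)(F)F)ccc2[C@H]2CCc3cc(S(=O)(=O)Nc4ncccn4)ccc32)cn1` gives 47000 nM

Among these three, compound 2 stands at the highest number. Its distance to compound 1 lies within the usual scatter of repeated measurements, so the two cannot be told apart on this read-out. Its distance to compound 3 lies beyond the scatter, so compound 2 comes out clearly more soluble than compound 3.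

Compound 4 `CN1CCN(c2cc(C(F)(F)F)ccc2[C@H]2CCOc3cc(S(=O)(=O)Nc4nccs4)ccc32)CC1` has not yet been measured in this assay. It differs from compound 2 in a single place: 4-methylpiperazin-1-yl in place of 2-oxo-1,3-oxazolidin-3-yl on an aromatic carbon. The shared core and the sulfonamide side of the molecule stay the same.

Within the data shown here, no two of the measured compounds differ in only one place, so there is no measured step of this kind to lean on, and the expectation rests on the three numbers alone. The step from compound 2 is expected to be small and upward, a 1.4-fold higher number from compound 2 to compound 4 (0.13 log units; within the scatter), and it may well stay within the scatter. Compound 4 is therefore expected to give about 400000 nM in this assay, with a range from 150000 nM to 1000000 nM.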

Compound 4, solubility: 176000 nM
The estimate for compound 4 lay 2.3-fold (0.36 log units) above the measured number; the range from low to high includes it.
By their numbers in this assay, from the lowest: compound 3; then compounds 4, 1 and 2 (each within the scatter of the next).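

At this position, an aromatic carbon ortho to a large group and meta to a trifluoromethyl group, the series now has its first measured step. In this assay, 4-methylpiperazin-1-yl in place of 2-oxo-1,3-oxazolidin-3-yl gives a 1.7-fold lower number from compound 2 to compound 4 (0.22 log units; within the scatter), so this read-out cannot tell the two compounds apart. For this one pair, then, a six-membered ring with two nitrogens and a five-membered ring with a nitrogen, two oxygens and a double bond outside the aromatic rings give values that lie within the usual scatter, and no measurement here speaks to the reason.

Still open, as far as these compounds go, is whether other groups on this carbon, such as a carboxylic acid, a morpholine ring or an open-chain dimethylamino group, would give a step beyond the scatter. Also open, from the compounds shown here alone, is whether the same exchange would give a similar step with another group on the sulfonamide side or with another core, since a single pair cannot show whether this result holds beyond compound 2 and compound 4.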